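The source may report more compounds than this note shows. Statements on the series, on what has been measured and on what is new or still open speak of the compounds shown alone.

Measured so far in an assay on cells for inhibition of MAP kinase-interacting serine/threonine-protein kinase 1 (Homo sapiens), read by mobility shift assay, with stated times of 10 min and 60 min, in the presence of a further agent that is not named here; on this read-out higher numbers stand for weaker inhibition and lower numbers for stronger inhibition:
compound 1 `CC(C)Oc1cc(-c2cncc(-c3cnn(C)c3)c2)ccc1C(N)=O` — 400 nM
compound 2 `Cc1n[nH]c(C)c1-c1cncc(-c2ccc(C(N)=O)c(OC(C)C)c2)c1` — 33 nM
compound 3 `NC(=O)c1ccc(-c2cccnc2)cc1OC1CCCCC1` — 1500 nM

Compound 3 gives the highest number of the three in this assay; compound 1 stands nearest to it, compound 2 furthest. For the measured compounds named here, the one measured step, a 12-fold lower number from compound 1 to compound 2 (1.08 log units; beyond the scatter), comes from 3,5-dimethyl-1H-pyrazol-4-yl in place of 1-methyl-1H-pyrazol-4-yl on an aromatic carbon, and does not touch the ether side chain.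

Compound 4 `CC(C)Oc1cc(-c2cccnc2)ccc1C(N)=O` differs from compound 3 by isopropyl in place of cyclohexyl on an oxygen on an aromatic ring. Going by the values given here, no measured step bears on this exchange directly. Compound 1 carries the same isopropoxy group together with a further pyrazolyl substituent on its pyridine and gives 400 nM. Compound 4 lacks that substituent, so its number is expected to sit above that of compound 1 and close to that of compound 3, with no step beyond the scatter clearly indicated. Compound 4 is therefore estimated at 1200 nM (range 400 nM to 4000 nM), corresponding to an expected 1.3-fold lower number from compound 3 to compound 4 (0.10 log units; within the scatter).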

Compound 4, half-maximal inhibitory concentration: 880 nM
The estimate for compound 4 lay 1.4-fold (0.13 log units) above the measured number; the measured number falls inside the stated range.
By their numbers in this assay, from the lowest: compound 2; then compound 1; then compounds 4 and 3 (each within the scatter of the next).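

In this assay, isopropyl in place of cyclohexyl on the oxygen gives a 1.7-fold lower number from compound 3 to compound 4 (0.23 log units; within the scatter), so the read-out does not separate these two ether groups on this otherwise unsubstituted compound pair. With the isopropoxy group held constant, hydrogen in place of 1-methyl-1H-pyrazol-4-yl gives a 2.2-fold higher number from compound 1 to compound 4 (0.34 log units; beyond the scatter), whereas hydrogen in place of 3,5-dimethyl-1H-pyrazol-4-yl gives a 27-fold higher number from compound 2 to compound 4 (1.43 log units; beyond the scatter). Among these compounds, the pyrazolyl substituent therefore moves the number more than the ether exchange does, and the size of that shift depends on which pyrazolyl group is present.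

No supporting data accompany these differences to account for them. Still open, going by these compounds, is whether cyclohexyloxy and isopropoxy also read alike alongside 3,5-dimethyl-1H-pyrazol-4-yl, and how a methoxy group or an ether chain ending in an amine would read at this oxygen.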